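Swapping a Five-Membered Ring for a Six-Membered One

The source may hold more compounds than are shown below. What is called first, only, known or untested is meant among the compounds shown, and "the series" means these compounds.

Measured so far:
compound 1, `O=C(NO)c1ccc(-c2nc(N3CCCCC3)c3ccccc3n2)cc1`, 66.4%
compound 2, `O=C(NO)c1ccc(-c2nc(N3CCCC3)c3ccc(Cl)cc3n2)cc1`, 54.6%

In an assay on isolated protein for inhibition of protein deacetylase HDAC6 (Homo sapiens), tested at 0.5 uM (a higher number here means more inhibition at the concentration tested (going by the name of the read-out), a lower number less inhibition), compound 1 gives 66.4%, while compound 2 gives 54.6%. Compound 2 therefore stands lowest of the two numbers, and the gap to compound 1 is beyond the usual scatter. Among the compounds with values here, no single-point step between these two has been worked out, since they differ in more than one place, so only their two values can be compared.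

Compound 3, `O=C(NO)c1ccc(-c2nc(N3CCCCC3)c3ccc(Cl)cc3n2)cc1`, has not yet been measured. It differs from compound 2 in one place: piperidin-1-yl in place of pyrrolidin-1-yl on an aromatic carbon. With that change, compound 3 carries the same ring as compound 1 while keeping the rest of compound 2. Because compound 1 gives 66.4% with this ring, compound 3 is expected to move upward, with the step of a number 5.4 percentage points higher from compound 2 to compound 3 (within the scatter) in this assay. The estimate for compound 3 is 60%, in a range from 45% to 75%.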

Compound 3, a percentage reported as inhibition, at one concentration (the size of the read-out at that concentration, not a potency): 59.6%
Compound 3: the middle estimate sits 0.4 percentage points above what was measured; measured number inside the range.
By their numbers in this assay, from the lowest: compounds 2, 3 and 1 (each within the scatter of the next, the first and the last beyond it).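

In this assay, piperidin-1-yl in place of pyrrolidin-1-yl on an aromatic carbon gives a number 5 percentage points higher from compound 2 to compound 3 (within the scatter), so this ring swap cannot be told apart from repeat-measurement noise. The other single change, chloro in place of hydrogen on an aromatic carbon, gives a number 6.8 percentage points lower from compound 1 to compound 3 (within the scatter), so neither change alone stands clear of the scatter. Nothing here measures why these steps come out as they do.

Going by these compounds, it remains open whether morpholin-4-yl or an open-chain amine such as dimethylamino at this position would give a step beyond the scatter. The same question stands for fluoro or methoxy in place of chloro.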